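The source may hold more compounds than are shown below. What is called first, only, known or untested is meant among the compounds shown, and "the series" means these compounds.

In a functional assay on cells (Cancer cell lines, Homo sapiens) for cytotoxicity, read by sulforhodamine B assay, with a stated time of 48 h (a lower number here means a stronger inhibitor of growth, a higher number a weaker inhibitor of growth), the measured compounds gave:
compound 1 `COc1ccc(OC)c(-c2cc(-c3ccccc3)nn2-c2ccc(S(=O)(=O)NC(C)=O)cc2)c1`: 18100 nM
compound 2 `Oc1ccc(O)c(-c2cc(-c3ccccc3)nn2-c2ccccc2)c1`: 18600 nM
compound 3 `CC(=O)NS(=O)(=O)c1ccc(-n2nc(-c3ccccc3)cc2-c2cc(O)ccc2O)cc1`: 90400 nM

Compound 3 holds the highest number of the three. It is reached by a 5.0-fold higher number from compound 1 to compound 3 (0.70 log units; beyond the scatter) and by a 4.9-fold higher number from compound 2 to compound 3 (0.69 log units; beyond the scatter), both beyond the scatter. Compound 4 `CC(=O)NS(=O)(=O)c1ccc(-n2nc(-c3ccccc3)cc2C2=CC(=O)C=CC2=O)cc1` differs from compound 3 by a group of 8 heavy atoms (6 carbon, 2 oxygen; one six-membered non-aromatic ring of carbon only) in place of a group of 8 heavy atoms (6 carbon, 2 oxygen; one six-membered aromatic ring of carbon only), on an aromatic carbon. Going by the values given here, no measured step concerns this exchange; the two recorded steps only place compound 3 relative to compound 1 and compound 2 and say nothing about the six-membered non-aromatic ring. The expectation for this assay is therefore loosely held, leaning toward a lower number for compound 4, estimated as a 3.0-fold lower number from compound 3 to compound 4 (0.48 log units; beyond the scatter). Compound 4 is expected to give about 30000 nM in this assay, within a range from 9000 nM to 100000 nM.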

Compound 4, concentration for 50% growth inhibition: 100000 nM
For compound 4 the middle estimate is 3.3-fold (0.52 log units) below the measured one; the measured number falls inside the stated range.
By their numbers in this assay, from the lowest: compounds 1 and 2 (each within the scatter of the next); then compounds 3 and 4 (each within the scatter of the next).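

In this assay, replacing the 2,5-dihydroxyphenyl group with the non-aromatic six-membered ring, which takes the hydrogen-bond donors from 2 to 0, gives a 1.1-fold higher number from compound 3 to compound 4 (0.04 log units; within the scatter), so this change does not separate the two compounds. The exchange for the 2,5-dimethoxyphenyl group gives a 5.5-fold higher number from compound 1 to compound 4 (0.74 log units; beyond the scatter), which places compound 4 with compound 3 and apart from compound 1. Nothing shown here offers an explanation for either step. The compounds shown leave open how a phenyl group carrying an amine or a carboxylic acid would read at this position.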